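Acetyl removal on a resorcylic open-chain analogue

The compounds below may be only part of what the source reports. "The series", "measured", "known", "first", "only" and "open" are said of these compounds alone.

Compound 1 `CCCC[C@H]1CCCC[C@H](C)[C@@H](O)c2cc(O)c(c(O)c2)[C@@H](CCCC)CCCC[C@H](C)[C@@H](O)c2cc(O)c1c(O)c2` is the macrocyclic reference; in an ADME assay on HaCaT cells (Homo sapiens) for cytotoxicity (a lower number here means a stronger inhibitor, a higher number a weaker inhibitor), compound 1 gives 5000 nM. Compound 2 `CCCCC(Cl)CCCC[C@H](C)[C@@H](OC(C)=O)c1cc(O)c([C@@H](CCCC)CCCC[C@H](C)[C@@H](OC(C)=O)c2cc(O)cc(O)c2)c(O)c1` is the open-chain, chlorinated analogue bearing acetoxy groups; in this assay compound 2 gives 25000 nM, the highest value of the pair, a gap from compound 1 that lies beyond the scatter. Among the measured compounds shown here, no single-change step between measured compounds is available, so the pair can only be read as its two values.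

Compound 3 `CCCCC(Cl)CCCC[C@H](C)[C@@H](O)c1cc(O)c([C@@H](CCCC)CCCC[C@H](C)[C@@H](OC(C)=O)c2cc(O)cc(O)c2)c(O)c1` differs from compound 2 by hydrogen in place of acetyl on an oxygen on a saturated carbon. Compound 3 keeps the chlorine and the open chain of compound 2, and moves part of the way toward the free hydroxyls of compound 1, which gives 5000 nM. A modest step toward a lower value is therefore expected, a 1.7-fold lower number from compound 2 to compound 3 (0.22 log units; within the scatter), but one that may well fall within the scatter. Compound 3 is estimated at 15000 nM, with a range from 6000 nM to 40000 nM.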

Compound 3, half-maximal inhibitory concentration: 25000 nM
For compound 3 the middle estimate is 1.7-fold (0.22 log units) below the measured one, and the stated range covers the measured number.
By their numbers in this assay, from the lowest: compound 1; then compounds 2 and 3 (each within the scatter of the next).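

In this assay, acetoxy to hydroxy at this oxygen on a saturated carbon gives no change at the digits printed from compound 2 to compound 3 (within the scatter) on the open-chain chlorinated analogue. At this position, hydrogen in place of acetyl therefore leaves the number unchanged at the digits printed, and this single acetyl shows no readable contribution to the value of compound 2. Among the compounds shown here, compound 3 still carries the second acetoxy group, the chlorine and the open chain, and no step in hand isolates any of these features. No evidence on the reason for this result is available.

Still open, as far as these compounds go, is whether hydrogen in place of acetyl on the second acetoxy group, alone or together with the first, would move the number. Also open, from the compounds shown here alone, is how a methyl ether or an amine would read at this position.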